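Amide and sulfonamide variation at the fused core

The source may report more compounds than this note shows. Statements on the series, on what has been measured and on what is new or still open speak of the compounds shown alone.

Measured in an ADME assay on the whole organism (Macaca fascicularis) for pharmacokinetics, read by LC-MS, using cassette dosing, at a dose of 1 mg/kg by the oral route; a higher number here means more compound in the circulation at the dose given, a lower number less compound in the circulation:
compound 1, `CCCCN(c1nc2c(NC(C)=O)cccc2o1)[C@H](C)c1ccc(-c2ccccc2-c2nnn[nH]2)cc1`: 26.6 nM
compound 2, `CCCCN(c1nc2c(C(=O)NC)cccc2o1)[C@H](C)c1ccc(-c2ccccc2-c2nnn[nH]2)cc1`: 19.7 nM
compound 3, `CCCCN(c1nc2c(NS(C)(=O)=O)cccc2o1)[C@H](C)c1ccc(-c2ccccc2-c2nnn[nH]2)cc1`: 49.9 nM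

On this assay compound 3 stands apart from compound 2 by a 2.5-fold higher number from compound 2 to compound 3 (0.40 log units; beyond the scatter), while its gap to compound 1 is within the scatter. Compound 4, `CCCCN(c1nc2c(C(=O)N(C)C)cccc2o1)[C@H](C)c1ccc(-c2ccccc2-c2nnn[nH]2)cc1`, differs from compound 3 by dimethylcarbamoyl in place of methanesulfonamido on an aromatic carbon. Among the measured compounds shown here, two measured steps bear on this. The step of a 2.5-fold higher number from compound 2 to compound 3 (0.40 log units; beyond the scatter) runs the opposite way, from a carbamoyl group to the sulfonamide; the step of a 1.4-fold lower number from compound 1 to compound 2 (0.13 log units; within the scatter), also at this carbon, stayed within the scatter. Reversing the sulfonamide-to-amide step suggests a modest fall. Compound 4 is therefore expected to give about 22 nM, within 8 nM to 60 nM, an expected step of a 2.3-fold lower number from compound 3 to compound 4 (0.36 log units; beyond the scatter).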

Compound 4, maximal plasma concentration: 54 nM
Beside the measured number, compound 4's estimate is 2.5-fold (0.39 log units) below it; the range from low to high includes it.
By their numbers in this assay, from the lowest: compounds 2, 1, 3 and 4 (each within the scatter of the next, the first and the last beyond it).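

In this assay methyl in place of hydrogen on the amide-type nitrogen raises the number (a 2.7-fold higher number from compound 2 to compound 4 (0.44 log units; beyond the scatter)), so at this aromatic carbon the amide hydrogen is not needed for the higher read-out. Dimethylcarbamoyl also shows that a sulfonamide is not required, as it cannot be told apart from methanesulfonamido (a 1.1-fold higher number from compound 3 to compound 4 (0.03 log units; within the scatter)), while it stands modestly above acetamido (a 2.0-fold higher number from compound 1 to compound 4 (0.31 log units; beyond the scatter)). No measurement at hand accounts for these steps.
Going by these compounds, whether larger groups on this amide nitrogen, such as diethylcarbamoyl or a pyrrolidine amide, hold the number remains open. So does the outcome with a carboxylic acid on this carbon.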